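The compounds below may be only part of what the source reports. "The series", "measured", "known", "first", "only" and "open" are said of these compounds alone.

The series was examined in a functional assay on MT4 cells (Homo sapiens) for antiproliferative activity, read by MTT assay, with a stated time of 96 h; on this read-out higher numbers stand for an effect only at larger amounts of compound and lower numbers for an effect already at smaller amounts. Compound 1 `COc1ccc(-c2[nH]c3ccccc3c2/C=C(\C#N)S(=O)(=O)c2ccccc2)cc1` gives 200 nM in this assay. Compound 2 `N#C/C(=C\c1c(-c2ccccc2)[nH]c2ccccc12)C(=O)N1CCCCC1` gives 9600 nM in this assay. Compound 3 `Cc1[nH]c2ccccc2c1C=C(C#N)C#N` gives 56000 nM in this assay, and this is the highest of the three numbers: compound 2 stands nearest to it and already lies lower by more than the scatter, while compound 1 stands furthest from it, also beyond the scatter. Compound 3 thus shows an effect only at the largest amounts among the three, and both compounds carrying an aryl group on the shared core sit well below it.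

Compound 4 `N#CC(C#N)=Cc1c[nH]c2ccccc12` has not yet been measured in this assay. It differs from compound 3 in one place: hydrogen in place of methyl on an aromatic carbon. Going by the values given here, no measured pair in this set isolates this change, so its size can only be guessed. Since the loss of a larger group at this position separates compound 3 from compound 1 and compound 2, removing the remaining methyl is expected to leave the number where it is or push it modestly higher rather than lower. The expected step of a 1.4-fold higher number from compound 3 to compound 4 (0.15 log units; within the scatter) is therefore small and, if anything, toward larger amounts. For compound 4 the estimate in this assay is 80000 nM, with a range from 20000 nM to 300000 nM.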

Compound 4, half-maximal effective concentration: 36000 nM
The estimate for compound 4 lay 2.2-fold (0.35 log units) above the measured number; the measured number falls inside the stated range.
By their numbers in this assay, from the lowest: compound 1; then compound 2; then compounds 4 and 3 (each within the scatter of the next).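

Going by these compounds alone, the pair of compound 3 and compound 4 is the first to isolate this position, the aromatic carbon next to the ring nitrogen, and in this assay it gives a 1.6-fold lower number from compound 3 to compound 4 (0.19 log units; within the scatter). Exchanging methyl for hydrogen at this place therefore leaves the read-out unchanged within the usual scatter, so the single carbon of the methyl group makes no discernible difference on this core with its two nitrile groups. Nothing available here accounts for this outcome.

Compound 1 and compound 2 differ from compound 3 in more than one place, so the compounds shown do not separate the contribution of their aryl groups at this position from that of the other changes they carry. Going by these compounds, it remains open how a phenyl group, a propyl chain, an amine or a carboxylic acid on this same aromatic carbon would read while the two nitrile groups of compound 3 stay in place, and thus whether any substituent here can move the number beyond the scatter.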